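The source may hold more compounds than are shown below. What is called first, only, known or untested is meant among the compounds shown, and "the series" means these compounds.

Measured so far:
- compound 1 `Cc1cc([C@@H]2C[C@H]2C(=O)O)ccc1-c1noc(-c2ccc(OC(C)C)c(C(F)(F)F)c2)n1`, which in an assay on CHO cells for displacement of a labelled ligand from sphingosine 1-phosphate receptor 2 (Homo sapiens) (on this read-out lower numbers stand for stronger inhibition and higher numbers for weaker inhibition), gives only a limit, > 10000 nM.
- compound 2 `Cc1cc(C(C)CC(=O)O)ccc1-c1noc(-c2ccc(OC(C)C)c(C(F)(F)F)c2)n1`, which in this assay likewise gives only a limit, > 10000 nM.

Compound 2 therefore stands at the limit of this assay, not at a number, and the same holds for compound 1. Among the measured compounds shown here, the one measured step, a step that the two limits leave unreadable from compound 1 to compound 2, cannot be read, because both ends sit at the limit of > 10000 nM in this assay, at which 2 of the 2 values shown sit. Compound 3 `Cc1cc(CC(C)C(=O)O)ccc1-c1noc(-c2ccc(OC(C)C)c(C(F)(F)F)c2)n1` is not yet measured; it differs from compound 2 by 2-carboxypropyl in place of 1-(carboxymethyl)ethyl on an aromatic carbon. For the measured compounds named here, no measured step bears on this change in a readable way, so no direction of effect can be drawn from the two measured compounds. The expectation is that compound 3 also stays at the limit, with an estimated value of 20000 nM, ranging from 5000 nM to 100000 nM. This estimate means an expected step that the limit leaves unreadable from compound 2 to compound 3, which is no change beyond the scatter.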

Compound 3, half-maximal inhibitory concentration: > 10000 nM
Compound 3: only a limit was reported; the forecaster's own chance of this, stated with the estimate: 85%; the middle value lies beyond the limit too.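

Among the compounds shown here, compound 3 also gives only a limit, so no step among compound 1, compound 2 and compound 3 can be read, because all three sit at one limit: the limit of > 10000 nM in this assay, at which 3 of the 3 values shown sit. The compounds shown leave open whether 2-carboxycyclopropyl, 1-(carboxymethyl)ethyl and 2-carboxypropyl differ at all in their effect on inhibition.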